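Shortening the Linker Between Core and Phenyl

The source may hold more compounds than are shown below. What is called first, only, known or untested is meant among the compounds shown, and "the series" means these compounds.

Compound 1 `COc1ccc(Oc2ccc3c(NCCCNCc4cccc(OC)c4O)ccnc3c2)cc1` gives 14500 nM in a physicochemical assay for solubility, with a stated time of 18 h, at pH 7.4; a lower number here means a less soluble compound, a higher number a more soluble compound. Compound 2 `COc1ccc(F)cc1CNCCCNc1ccnc2cc(CCc3ccccc3)ccc12` gives 4200 nM. Compound 3 `COc1cccc(CNCCCNc2ccnc3cc(-c4cc(C(F)(F)F)cc(C(F)(F)F)c4)ccc23)c1O` gives 32000 nM.

Among these three, compound 2 stands lowest in this assay, with compound 1 the nearest and compound 3 the furthest, both gaps beyond the usual scatter. Among the compounds with values here, compound 4 `COc1ccc(F)cc1CNCCCNc1ccnc2cc(Cc3ccccc3)ccc12` differs from compound 2 in one place: phenyl in place of benzyl on a saturated chain carbon bound to an aromatic carbon No measured pair shows the same change, so the expectation rests on compound 2 alone. One carbon fewer in the link is expected to move the number only slightly, if at all, and the step from compound 2 to compound 4 is estimated at a 1.3-fold higher number from compound 2 to compound 4 (0.12 log units; within the scatter), within the scatter. Compound 4 is therefore expected near 5500 nM, between 2500 nM and 12000 nM.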

Compound 4, solubility: 4200 nM
The estimate for compound 4 lay 1.3-fold (0.12 log units) above the measured number; measured number inside the range.
By their numbers in this assay, from the lowest: compounds 2 and 4 (each within the scatter of the next); then compound 1; then compound 3.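

In this assay, the change of phenyl in place of benzyl on a saturated chain carbon bound to an aromatic carbon, which reads equally as phenethyl to benzyl, gives no change at the digits printed from compound 2 to compound 4 (within the scatter). Within the data shown here, this is the only step here that differs in one place, and it shows that this link can be shortened without the read-out moving beyond the scatter, at least for this single pair. No measurement at hand accounts for this result.

Going by these compounds, whether a longer chain carrying the phenyl, or an amine or a carboxylic acid in its place, would leave the number equally unmoved remains open.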